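Isopropyl to cyclopentyl on the sulfur

A few compounds are considered here, and "the series" means these few. Any claim that something is new, unique, unknown or untested is made for them only; others in the source may bear on it.

In an ADME assay on MT4 cells (Homo sapiens) for activation, read by MTT assay (a higher number here means that more compound is tolerated, a lower number that less compound is tolerated), compound 1 `CC(C)Sc1nc(C(C)c2c(F)cccc2Cl)cc(=O)[nH]1` gives > 75000 nM, which is a limit and not a number. Compound 2 `CCc1c(C(C)c2c(F)cccc2Cl)nc(SC(C)C)[nH]c1=O` gives > 3000 nM, likewise only a limit. Within the data shown here, compound 2 therefore has no measured number, and the one other value beside it offers none either. The next change leads to compound 3 `CCc1c(C(C)c2c(F)cccc2Cl)nc(SC2CCCC2)[nH]c1=O` and is cyclopentyl in place of isopropyl on a sulfur, with cyclopentyl in place of isopropyl on a sulfur. Among the measured compounds shown here, the only measured step is a step that the two limits leave unreadable from compound 1 to compound 2. It concerns ethyl in place of hydrogen on an aromatic carbon, not the group on the sulfur, so it offers no size or direction to carry over. No shift beyond the scatter is therefore expected in this assay. Taken against the limit, the expected step is a step that the limit leaves unreadable from compound 2 to compound 3. For compound 3 the estimate is 5500 nM, with an expected range from 1500 nM to 30000 nM.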

Compound 3, half-maximal cytotoxic concentration: > 3000 nM
Compound 3: no number, only a limit; the forecaster's own chance of this, stated with the estimate: 60%; the middle value lies beyond the limit too.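

Compound 2 and compound 3 are both known in this assay only as limits, so the step between them cannot be read. The compounds shown leave open whether cyclopentyl in place of isopropyl on the sulfur shifts the tolerated concentration at all, and by how much.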